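Replacing one ring group on compound 3

The source may report more compounds than this note shows. Statements on the series, on what has been measured and on what is new or still open speak of the compounds shown alone.

Compound 1 `Cc1cc2c(Oc3cnc(C(=O)N4CC(C)C4)cn3)cc(C(=O)Nc3cnccn3)cc2o1`: < 9.6 mL/min/kg
Compound 2 `COC1CN(C(=O)c2cnc(Oc3cc(C(=O)Nc4cnccn4)cc4oc(C)cc34)cn2)C1`: < 9.2 mL/min/kg
Compound 3 `Cc1cc2c(Oc3cnc(C(=O)N4CC(C)(O)C4)cn3)cc(C(=O)Nc3cnccn3)cc2o1`: < 8 mL/min/kg

In an ADME assay (liver) for metabolic stability, with Liver microsome (Homo sapiens) as the target, using microsomes (a lower number here means slower removal, a higher number faster removal of the compound), compound 3 stands at < 8 mL/min/kg, which is a limit and not a number. The other two entries are limits as well, so the three compounds cannot be ranked. Compound 4 `Cc1cc2c(Oc3cnc(C(=O)N4CC5(COC5)C4)cn3)cc(C(=O)Nc3cnccn3)cc2o1` keeps the shared core and changes one group on a carbonyl carbon: a group of 7 heavy atoms (5 carbon, 1 nitrogen, 1 oxygen; 2 four-membered non-aromatic rings with 1 hetero atom each) in place of a group of 6 heavy atoms (4 carbon, 1 nitrogen, 1 oxygen; one four-membered non-aromatic ring with 1 hetero atom), on a carbonyl carbon. The measured steps that bear on this change are a step that the two limits leave unreadable from compound 1 to compound 3 and a step that the two limits leave unreadable from compound 2 to compound 3, and neither gives a size. With no measured size to build on, no step beyond the scatter is expected in this assay. The expected change is a number no lower from compound 3 to compound 4 (the limit leaves the size open). Compound 4 is estimated at 8 mL/min/kg, with an expected range from 5 mL/min/kg to 16 mL/min/kg.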

Compound 4, clearance: 12.9 mL/min/kg
Compound 4: the middle estimate sits 1.6-fold (0.21 log units) below what was measured, within the range that was stated.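

For the compounds shown here, compound 4 is the first compound here with an actual number in this assay, so changes on this carbonyl carbon now have a minimum size, while the steps among the three earlier limits still cannot be read. The new steps are an at least 1.6-fold higher number from compound 3 to compound 4 (0.20 log units; that floor lies within the scatter), an at least 1.4-fold higher number from compound 2 to compound 4 (0.14 log units; that floor lies within the scatter) and an at least 1.3-fold higher number from compound 1 to compound 4 (0.12 log units; that floor lies within the scatter). These are only minimum sizes. A real rise is neither shown nor ruled out. Going by these compounds alone, how far the earlier compounds lie under their limits stays open. Also open, from the compounds shown here alone, is where a morpholin-4-yl group would fall on this carbonyl carbon.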